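Swapping Phenylsulfanyl for Methyl on a Shared Fused Core

This account rests on a few compounds, and the source may have more. Where it says the series, first, only, none or still open, it means among the compounds named here.

Compound 1 `c1ccc2oc(-c3cn4nc(C5CC5)sc4n3)cc2c1` gives 53% in an ADME assay on microsomes from liver (Rattus norvegicus) for metabolic stability, with a stated time of 10 min (on this read-out lower numbers stand for a less stable compound and higher numbers for a more stable compound), and compound 2 `CCOc1nn2cc(-c3cc4ccccc4o3)nc2s1` gives 37% in this assay. For the measured compounds named here, that pair is the only measured step: a number 16 percentage points lower from compound 1 to compound 2 (beyond the scatter). Compound 3 `c1ccc(Sc2nn3cc(-c4cc5ccccc5o4)nc3s2)cc1` carries a phenylsulfanyl group on the shared core, and in this assay compound 3 stands at "not determined" (no result reported), so no number anchors it. Compound 4 `Cc1nn2cc(-c3cc4ccccc4o3)nc2s1` differs from compound 3 in one place: methyl in place of phenylsulfanyl on an aromatic carbon. Going by the values given here, no measured step covers a methyl group at that position, so any expectation rests only on the spread between compound 1 and compound 2, both of which stay in the middle of the read-out. Compound 4 is therefore expected to give about 45% in this assay, within a range from 25% to 65%, and its direction relative to compound 3 cannot be expected at all.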

Compound 4, percent of the compound remaining: 4%
Compound 4: the middle estimate sits 41 percentage points above what was measured; the whole stated range lies above it.
By their numbers in this assay, from the lowest: compound 4; then compound 2; then compound 1.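

In this assay, methyl at this position goes with far less compound remaining than either ethoxy or cyclopropyl: a number 33 percentage points lower from compound 2 to compound 4 (beyond the scatter) and a number 49 percentage points lower from compound 1 to compound 4 (beyond the scatter). Both steps are large, whereas the earlier step between cyclopropyl and ethoxy was modest, so changing the group on this aromatic carbon can take the read-out from the middle almost to the bottom. No measured evidence accounts for this result. The change from phenylsulfanyl to methyl cannot be read. As far as these compounds go, how an amine or a longer chain at this carbon would compare remains open.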